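A few compounds are considered here, and "the series" means these few. Any claim that something is new, unique, unknown or untested is made for them only; others in the source may bear on it.

Compound 1, `COc1cc(N(Cc2cccc(C)c2)S(=O)(=O)c2ccc(C)cc2)cc(OC)c1OC`, gives 8580 nM in a functional assay on PC-3 cells (Homo sapiens) for inhibition, read by MTT assay, with a stated time of 48 h; on this read-out higher numbers stand for weaker inhibition and lower numbers for stronger inhibition.
Compound 2, `COc1cc(N(Cc2nc3ccccc3[nH]2)S(=O)(=O)c2ccc(Br)cc2)cc(OC)c1OC`, gives 6890 nM in this assay.
Compound 3, `Cc1ccc(S(=O)(=O)N(Cc2nc3ccccc3[nH]2)c2ccc(F)cc2)cc1`, gives 45000 nM in this assay.

Compound 3 stands at the highest number of the three, so it is the weakest inhibitor among them; its gaps to compound 1 and to compound 2 both lie beyond the scatter of repeated measurements. The step to compound 4, `Cc1ccc(N(Cc2nc3ccccc3[nH]2)S(=O)(=O)c2ccc(C)cc2)cc1`, is methyl in place of fluoro on an aromatic carbon. For the measured compounds named here, no measured pair shows this same change, so there is no measured direction to lean on, and compounds 1 and 2 differ from compound 3 in other places as well. The expected step in this assay is estimated as a 1.3-fold lower number from compound 3 to compound 4 (0.11 log units; within the scatter), a step that is not expected to reach beyond the scatter. Compound 4 is therefore expected to give about 35000 nM, in a range from 12000 nM to 100000 nM.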

Compound 4, half-maximal inhibitory concentration: 48900 nM
The estimate for compound 4 lay 1.4-fold (0.15 log units) below the measured number; the measured number falls inside the stated range.
By their numbers in this assay, from the lowest: compounds 2 and 1 (each within the scatter of the next); then compounds 3 and 4 (each within the scatter of the next).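

In this assay, putting methyl in place of fluoro on this aromatic carbon, para to a large group, gives a 1.1-fold higher number from compound 3 to compound 4 (0.04 log units; within the scatter), so on this read-out the 4-fluorophenyl and 4-methylphenyl compounds cannot be told apart. No measurement on these compounds offers an explanation for this result. From the compounds shown here alone, whether an amine, a carboxylic acid or a longer chain at this place would give a clearly different number remains open. Also open, going by these compounds, is whether the same swap would give a similarly small step on another core, such as that of compound 2.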